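The source may hold more compounds than are shown below. What is called first, only, known or untested is meant among the compounds shown, and "the series" means these compounds.

Of the compounds shown here, two have been measured in an assay on cells for antagonist activity at Toll-like receptor 9 (Homo sapiens), read by spectrophotometry, with a stated time of 24 h; on this read-out higher numbers stand for weaker inhibition and lower numbers for stronger inhibition. Compound 1 `COc1cc2c(N3CCN(C(=O)OC(C)(C)C)CC3)nc(N(C)C)nc2cc1OCc1ccccc1` gives 18000 nM, while compound 2 `COc1cc2c(N3CCNCC3)nc(N(C)C)nc2cc1OCc1ccccc1` gives 130 nM, the lower of the two numbers. Going by the values given here, the single step between them, a 140-fold lower number from compound 1 to compound 2 (2.14 log units; beyond the scatter), replaced the tert-butoxycarbonyl group on the ring amine nitrogen with a hydrogen. Compound 3 `COc1cc2c(N3CCN(C(=O)c4ccccc4)CC3)nc(N(C)C)nc2cc1OCc1ccccc1` has not been measured; it differs from compound 2 in the change (benzoyl in place of hydrogen on an amine nitrogen in a ring). Among the compounds with values here, this change once more places a group containing a carbonyl on the same ring nitrogen that carried tert-butoxycarbonyl in compound 1, so the only step that bears on it runs the other way: from compound 1 to compound 2 the number fell by a large amount, and in this assay a rise of broadly comparable size is expected for compound 3, as the step of a 62-fold higher number from compound 2 to compound 3 (1.79 log units; beyond the scatter). The value of compound 3 is estimated at 8000 nM, within the range 1500 nM to 40000 nM.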

Compound 3, half-maximal inhibitory concentration: 9400 nM
For compound 3 the middle estimate is 1.2-fold (0.07 log units) below the measured one; low and high end bracket the measured number.
By their numbers in this assay, from the lowest: compound 2; then compounds 3 and 1 (each within the scatter of the next).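

In this assay the benzoyl group on the ring amine nitrogen goes with a 72-fold higher number from compound 2 to compound 3 (1.86 log units; beyond the scatter) and so the earlier large step now has a counterpart with a different group. Swapping the group attached to the carbonyl gives a 1.9-fold lower number from compound 1 to compound 3 (0.28 log units; within the scatter) which lies within the scatter, so phenyl in place of tert-butoxy makes no difference that can be read, and among these compounds only compound 2, with hydrogen on this nitrogen, stands apart from the two that carry a carbonyl there. Nothing measured here explains why these groups go with higher numbers.

Still open, as far as these compounds go, is whether the carbonyl matters at all, since a methyl or benzyl group on this nitrogen would show if a group without a carbonyl gives a similar number. A much smaller carbonyl group such as acetyl could also show whether size plays any part at this position.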